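The source may hold more compounds than are shown below. What is called first, only, known or untested is meant among the compounds shown, and "the series" means these compounds.

Measured compounds:
- compound 1, `Cc1nc(C)c(C(=O)Nc2ccc3nc(NC(=O)C4CCCCC4)sc3c2)s1`: 0.39 ug/mL
- compound 2, `O=C(Nc1nc2ccc(N/C(S)=N/c3ccccc3OC(F)(F)F)cc2s1)C1CCCCC1`: 2.3 ug/mL
- compound 3, `CCCOC(=O)Nc1nc2ccc(NC(=O)c3c(Cl)cccc3Cl)cc2s1`: 0.0025 ug/mL

In a functional assay on WI-38 VA13 cells (Homo sapiens) for cytotoxicity (a higher number here means that more compound is needed for the effect, a lower number that less compound is needed), compound 3 gives the lowest number of the three. Against compound 1 the gap is beyond the scatter, and against compound 2 it is wider still, also beyond the scatter. For the measured compounds named here, no two measured compounds differ in only one place, so no single structural step has a measured size here.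

Compound 4, `O=C(Nc1ccc2nc(NCC3CCCCC3)sc2c1)c1c(Cl)cccc1Cl`, has not yet been measured in this assay. It differs from compound 3 in one place: cyclohexylmethyl in place of propoxycarbonyl on a nitrogen on an aromatic ring. The group that leaves carries a double bond outside aromatic rings and two hydrogen-bond acceptors; the group that enters carries a six-membered non-aromatic ring and no acceptors. Going by the values given here, no measured pair shows this change, so its size is unknown from the data; the expectation rests on compound 3 standing alone at the low end, with compound 1 and compound 2 both far above it.

Compound 4 is expected to give a higher number than compound 3 in this assay, with a step of a 40-fold higher number from compound 3 to compound 4 (1.60 log units; beyond the scatter) expected, beyond the scatter but still leaving compound 4 below compound 1. The estimate for compound 4 is 0.1 ug/mL, within the range 0.01 ug/mL to 1 ug/mL.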

Compound 4, half-maximal effective concentration: 4.3 ug/mL
The estimate for compound 4 lay 43-fold (1.63 log units) below the measured number; the measured number lies above the stated range.
By their numbers in this assay, from the lowest: compound 3; then compound 1; then compounds 2 and 4 (each within the scatter of the next).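

In this assay, for the compounds shown here, the nitrogen on an aromatic ring proves highly sensitive to its substituent: cyclohexylmethyl in place of propoxycarbonyl gives a 1700-fold higher number from compound 3 to compound 4 (3.24 log units; beyond the scatter) and is the first single change with a measured size. This one change removes a double bond outside aromatic rings and both hydrogen-bond acceptors, and it adds a six-membered non-aromatic ring, leaving these features unseparated. Nothing available bears on the reason for the size of this step.

On these data alone, it remains open whether the carbonyl or the carbon portion of the substituent governs the result, which a plain propyl group or an acetyl group on the same nitrogen would help to separate. As far as these compounds go, the response to a free amine or a longer carbamate chain such as butoxycarbonyl at this place also remains open.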